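The source may report more compounds than this note shows. Statements on the series, on what has been measured and on what is new or still open speak of the compounds shown alone.

Within the data shown here, in an in vivo ADME assay on the whole organism (plasma) for pharmacokinetics, with Rattus norvegicus as the target (on this read-out lower numbers stand for slow clearance and higher numbers for fast clearance), compound 3 (`Fc1cnc(-c2cc(-c3ccc(F)c(-c4ncccc4F)c3)cnn2)c(F)c1`) gives 3 mL/min/kg, the lowest of the three numbers so far. Compound 2 (`Fc1cnc(-c2cc(-c3cnnc(-c4c(F)cncc4F)c3)ccc2F)c(F)c1`) gives 59 mL/min/kg, and compound 1 (`Fc1cnccc1-c1cc(-c2ccc(F)c(-c3ncccc3F)c2)cnn1`) gives 91 mL/min/kg.

Compound 4 (`Fc1cnc(-c2cc(-c3ccc(F)c(-c4ncc(F)cc4F)c3)cnn2)c(F)c1`) departs from compound 3 by one change: fluoro in place of hydrogen on an aromatic carbon. This is fluoro in place of hydrogen on an aromatic carbon, turning 3-fluoropyridin-2-yl into 3,5-difluoropyridin-2-yl.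

Among the measured compounds shown here, only one measured step is available: a 30-fold lower number from compound 1 to compound 3 (1.48 log units; beyond the scatter), a large step with 3,5-difluoropyridin-2-yl in place of 3-fluoropyridin-4-yl. It shows that a single replacement can move this assay strongly in this series, but it is a different change at a different site. For the measured compounds named here, no measured step isolates the addition of one fluoro, so its size cannot be carried over.

No step beyond the scatter is therefore expected, with more uncertainty upward from the 3 mL/min/kg of compound 3. The estimated change is a 1.7-fold higher number from compound 3 to compound 4 (0.22 log units; within the scatter). For compound 4 the expected clearance is 5 mL/min/kg, with an estimated range of 2 mL/min/kg to 15 mL/min/kg.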

Compound 4, clearance: 1.3 mL/min/kg
Compound 4: middle estimate off by 3.8-fold (0.59 log units), on the high side; the whole stated range lies above it.
By their numbers in this assay, from the lowest: compound 4; then compound 3; then compounds 2 and 1 (each within the scatter of the next).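

Fluoro on this aromatic carbon, two atoms from the ring nitrogen and para to a large group, gives a 2.3-fold lower number from compound 3 to compound 4 (0.36 log units; beyond the scatter) in this assay, so this small change still lowers a clearance that was already the lowest in the set. The replacement of 3,5-difluoropyridin-4-yl by 3,5-difluoropyridin-2-yl gives a 45-fold lower number from compound 2 to compound 4 (1.66 log units; beyond the scatter), a far larger step at a different site than the one from the added fluoro. Nothing available explains either step.

As far as these compounds go, whether this position favours fluoro specifically stays open, as a chloro, methyl, nitrile or amine group here could move clearance either way. From the compounds shown here alone, whether the same fluoro step holds with other groups elsewhere on the core also stays open, as it rests on a single pair.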